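Changing the anilide aryl group: expected cytotoxicity of compound 3

A few compounds are considered here, and "the series" means these few. Any claim that something is new, unique, unknown or untested is made for them only; others in the source may bear on it.

Measured so far:
- Compound 1, `Cc1nc(C(NC(=O)C(=O)Nc2ccc(Cl)cc2)C2CCCCN2C)sc1CCO`: 36000 nM
- Compound 2, `Cc1nc(C(NC(=O)C(=O)Nc2ccc(C(F)(F)F)cc2)C2CCCCN2)sc1CO`: > 75500 nM (a limit, not a number)

Of the compounds shown here, two have been measured in an ADME assay on TZM-b1 cells (Homo sapiens) for cytotoxicity, read by XTT assay, with a stated time of 3 days; on this read-out lower numbers stand for higher toxicity in this test and higher numbers for lower toxicity in this test. Compound 1 gives 36000 nM in this assay. For compound 2, this assay reports only the limit > 75500 nM, so its true half-maximal cytotoxic concentration is not known as a number; it stands at the limit of > 75500 nM in this assay, at which 1 of the 2 values shown sits. For the measured compounds named here, compound 1 and compound 2 differ in several places at once, so no single step between them can be read.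

The unmeasured compound 3, `Cc1ccc(NC(=O)C(=O)NC(c2nc(C)c(CO)s2)C2CCCCN2)c(F)c1`, differs from compound 2 in one place: 2-fluoro-4-methylphenyl in place of 4-(trifluoromethyl)phenyl on an amide-type nitrogen. Going by the values given here, no measured step of the same kind is available, so the size of the change in this assay is uncertain; a step of no more than the usual scatter, in either direction, is expected, an at least 1.2-fold lower number from compound 2 to compound 3 (0.09 log units; that floor lies within the scatter). Compound 3 is thus expected to give about 60000 nM in this assay, within roughly 25000 nM to 150000 nM, and a limit rather than a number is quite possible.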

Compound 3, half-maximal cytotoxic concentration: > 88000 nM
Compound 3 gave a limit, no number; the forecaster's own chance of this, stated with the estimate: 50%; middle value at least 1.4-fold (0.16 log units) from the limit.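

In this assay compound 3 gives > 88000 nM, which is a limit and not a number. For the compounds shown here, compound 2 also stands only at a limit, and no step between compound 2 and compound 3 can be read. The compounds shown leave open whether exchanging 4-(trifluoromethyl)phenyl for 2-fluoro-4-methylphenyl changes the half-maximal cytotoxic concentration at all.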